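Acetyl for methylsulfonyl on the amine nitrogen

The source may hold more compounds than are shown below. What is called first, only, known or untested is meant among the compounds shown, and "the series" means these compounds.

Two compounds carry numbers in an assay on cells for inhibition of Ectonucleotide pyrophosphatase/phosphodiesterase family member 1 (Homo sapiens), with a stated time of 60 min, tested at 1 uM; on this read-out higher numbers stand for more inhibition at the one concentration tested (going by the name of the read-out) and lower numbers for less inhibition. Compound 1 `CCCOc1cc2c(Cl)ncnc2cc1OC` gives 29%. Compound 2 `COc1cc2ncnc(N3CCC(CCNS(C)(=O)=O)CC3)c2cc1OC` gives 12%, the lower of the two, with compound 1 standing higher by more than the usual scatter; these two differ in more than one place, so only their two values are on hand. Compound 3 `COc1cc2ncnc(N3CCC(CCNC(C)=O)CC3)c2cc1OC` is not yet measured; it differs from compound 2 by acetyl in place of methylsulfonyl on an amine nitrogen. Among the measured compounds shown here, no measured pair isolates this change. The expected step is a number 2 percentage points lower from compound 2 to compound 3 (within the scatter), that is none beyond the scatter. Compound 3 is estimated at 10%, ranging from -5% to 27%.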

Compound 3, a percentage reported as inhibition, at one concentration (the size of the read-out at that concentration, not a potency): 9%
Compound 3: middle estimate off by 1 percentage points, on the high side; measured number inside the range.
By their numbers in this assay, from the lowest: compounds 3 and 2 (each within the scatter of the next); then compound 1.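

Among the compounds shown here, the pair gives the first isolated reading of this change: in this assay, acetyl in place of methylsulfonyl on the amine nitrogen gives a number 3 percentage points lower from compound 2 to compound 3 (within the scatter). At this position, the two groups are therefore not told apart on this read-out, and the sulfur-bearing group shows no distinct effect. Nothing on hand accounts for this result.

Still open, going by these compounds, is whether any other group here, such as a benzoyl or a urea, would move the number beyond the scatter. On these data alone, a longer chain in place of the 2-acetamidoethyl group is equally open.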